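The source may hold more compounds than are shown below. What is called first, only, known or untested is meant among the compounds shown, and "the series" means these compounds.

Working notes on the series. Three compounds carry a measured value. Compound 1 `Cc1cn([C@@H]2O[C@H](CO[Si](C)(C)C(C)(C)C)[C@@]3(OS(=O)(=O)C=C3NCCC(N)=O)[C@H]2O[Si](C)(C)C(C)(C)C)c(=O)n(C)c1=O` gives 20000 nM in a functional assay on MT4 cells (Homo sapiens); a higher number here means that more compound is tolerated, a lower number that less compound is tolerated. Compound 2 `COC(=O)CNC1=CS(=O)(=O)O[C@@]12[C@@H](CO[Si](C)(C)C(C)(C)C)O[C@@H](n1cc(C)c(=O)n(C)c1=O)[C@@H]2O[Si](C)(C)C(C)(C)C` gives 105000 nM in this assay, and compound 3 `CC(=O)NC1=CS(=O)(=O)O[C@@]12[C@@H](CO[Si](C)(C)C(C)(C)C)O[C@@H](n1cc(C)c(=O)n(C)c1=O)[C@@H]2O[Si](C)(C)C(C)(C)C` gives 10700 nM in this assay. Compound 3 holds the lowest of the three numbers; its nearest neighbour is compound 1, with a 1.9-fold lower number from compound 1 to compound 3 (0.27 log units; within the scatter) lying within the scatter, and its furthest is compound 2, with a 9.8-fold lower number from compound 2 to compound 3 (0.99 log units; beyond the scatter) beyond the scatter. The remaining step, a 5.3-fold higher number from compound 1 to compound 2 (0.72 log units; beyond the scatter), is also beyond the scatter.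

Compound 4 `Cc1cn([C@@H]2O[C@H](CO[Si](C)(C)C(C)(C)C)[C@@]3(OS(=O)(=O)C=C3NC(=O)NC(=O)c3ccccc3)[C@H]2O[Si](C)(C)C(C)(C)C)c(=O)n(C)c1=O` is not yet measured. Its change from compound 3 is benzamido in place of methyl on a carbonyl carbon: acetyl becomes benzoylcarbamoyl, acetamido becomes (benzoylcarbamoyl)amino. Going by the values given here, the steps that bear on it are those altering the group on the amine nitrogen, namely a 9.8-fold lower number from compound 2 to compound 3 (0.99 log units; beyond the scatter) and a 1.9-fold lower number from compound 1 to compound 3 (0.27 log units; within the scatter); together they show that such changes move the number by modest amounts in either direction, never far. The present change is larger than either, adding a six-membered aromatic ring and a further donor and acceptor, so a modest step in this assay is expected, direction uncertain, leaning upward. Compound 4 is therefore estimated at 20000 nM, between 5000 nM and 80000 nM, a step of a 1.9-fold higher number from compound 3 to compound 4 (0.27 log units; within the scatter).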

Compound 4, half-maximal cytotoxic concentration: 3330 nM
The estimate for compound 4 lay 6.0-fold (0.78 log units) above the measured number, and the stated range ends above it.
By their numbers in this assay, from the lowest: compound 4; then compounds 3 and 1 (each within the scatter of the next); then compound 2.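

In this assay, benzamido in place of methyl on a carbonyl carbon gives a 3.2-fold lower number from compound 3 to compound 4 (0.51 log units; beyond the scatter) and so shifts the number beyond the scatter in the direction of less compound tolerated. Benzoylcarbamoyl on the amine nitrogen also gives a 6.0-fold lower number from compound 1 to compound 4 (0.78 log units; beyond the scatter) and a 32-fold lower number from compound 2 to compound 4 (1.50 log units; beyond the scatter), the second being the first large step in the series and showing that a change at this nitrogen can reach well beyond the modest steps seen among compounds 1, 2 and 3. No measurement at hand speaks to what lies behind these steps.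

On these data alone, whether the step follows the six-membered aromatic ring or the added amide-type nitrogen and carbonyl remains open. A plain benzoyl on the amine nitrogen, or a phenylcarbamoyl group there, would separate the two.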